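From 4-methylphenyl to 3,4-dichlorophenyl on a shared core

The source may hold more compounds than are shown below. What is called first, only, known or untested is meant among the compounds shown, and "the series" means these compounds.

In a functional assay on A549 cells (Homo sapiens) for antiproliferative activity, read by MTT assay, with a stated time of 72 h (a higher number here means a weaker inhibitor, a lower number a stronger inhibitor), compound 1 `COc1cc(-n2ncnc2-c2ccc(C)cc2)cc(OC)c1OC` gives 1100 nM. Among the measured compounds shown here, this is the only exact number available so far, which makes compound 1 the single firm reference point. Compound 2 `COc1cc(-c2ncnn2-c2ccc([N+](=O)[O-])cc2)cc(OC)c1OC` gives > 10000 nM, which is a limit of the assay and not a number.

The next compound to be tested is compound 3 `COc1cc(-n2ncnc2-c2ccc(Cl)c(Cl)c2)cc(OC)c1OC`. It keeps the core of compound 1 and changes one group: 3,4-dichlorophenyl in place of 4-methylphenyl on an aromatic carbon. In words, 3,4-dichlorophenyl stands in place of 4-methylphenyl on an aromatic carbon of a five-membered aromatic ring with 3 nitrogen.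

For the measured compounds named here, no measured pair yet shows what this swap does, so the expectation starts from compound 1 at 1100 nM and stays cautious. In this assay, the expected change is a small one toward weaker inhibition, a 1.6-fold higher number from compound 1 to compound 3 (0.21 log units; within the scatter), and it may not exceed the usual scatter. For compound 3, the estimated value is 1800 nM, with an expected range from 450 nM to 7000 nM.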

Compound 3, half-maximal inhibitory concentration: > 10000 nM
Compound 3: only a limit was reported; the forecaster's own chance of this, stated with the estimate: 8%; middle value at least 5.5-fold (0.74 log units) away from the limit.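

On this aromatic carbon of the shared core, 3,4-dichlorophenyl in place of 4-methylphenyl gives, in this assay, an at least 9.0-fold higher number from compound 1 to compound 3 (0.95 log units; beyond the scatter). Among the compounds shown here, this is the first measured pair, and it shows that a change at this one place can lower activity beyond the usual scatter, so the aryl group here cannot be swapped freely. The value of compound 3 is a limit and not a number, so only the lower bound of the step can be read, and the true size of the loss remains unknown because the result sits at the assay's ceiling: the limit of > 10000 nM in this assay, at which 2 of the 3 values shown sit.

As far as these compounds go, it remains open whether a smaller change on this phenyl ring, such as a single fluorine or a methoxy group in place of the methyl, would keep the activity of compound 1 at 1100 nM. Also open, from the compounds shown here alone, are whether a single chlorine would produce the same step and whether an amine or a carboxylic acid on this ring would bring a stronger or a weaker result.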